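From Pyrrolidin-1-yl to Piperidin-1-yl at the Assay Limit

The source may report more compounds than this note shows. Statements on the series, on what has been measured and on what is new or still open speak of the compounds shown alone.

Compound 2 `O=C(CN1CCCC1)Nc1ccc2ncnc(Nc3ccc(Cl)c(C(F)(F)F)c3)c2c1` was tested in a functional assay on MCF7 cells (Homo sapiens) for antiproliferative activity, read by MTT assay, with a stated time of 48 h; on this read-out higher numbers stand for weaker inhibition and lower numbers for stronger inhibition. Compound 2 gives > 100000 nM, which is a limit of the assay and not a number. Within the data shown here, its only neighbour on the measured data is compound 1 `O=C(CN1CCCCC1)Nc1ccc2ncnc(Nc3ccc(Cl)cc3)c2c1`. Compound 1 gives > 100000 nM, which is also a limit. Every measurement so far therefore sits at one point: the limit of > 100000 nM in this assay, at which 2 of the 2 values shown sit.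

Compound 3 `O=C(CN1CCCCC1)Nc1ccc2ncnc(Nc3ccc(Cl)c(C(F)(F)F)c3)c2c1` differs from compound 2 as follows: piperidin-1-yl in place of pyrrolidin-1-yl on a saturated chain carbon bound to a carbonyl carbon. It carries piperidin-1-yl in place of pyrrolidin-1-yl on a saturated chain carbon bound to a carbonyl carbon. Compound 1 also carries piperidin-1-yl and reaches only its limit of > 100000 nM, so no gain is expected from this change. In this assay the expected step is a number no higher from compound 2 to compound 3 (the limit leaves the size open), with nothing estimated beyond the scatter. For compound 3 the estimated value is 100000 nM, expected to fall between 40000 nM and 200000 nM.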

Compound 3, half-maximal inhibitory concentration: > 100000 nM
Compound 3: a limit, no number; the forecaster's own chance of this, stated with the estimate: 80%; the middle value lies on the limit itself.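

Compound 3 gives only a limit and no number, like compound 1 and compound 2, so no step from either neighbour to compound 3 can be read: the limit of > 100000 nM in this assay, at which 3 of the 3 values shown sit.

The compounds shown leave open whether piperidin-1-yl, pyrrolidin-1-yl or trifluoromethyl makes any difference to antiproliferative activity.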